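A Methyl Added to a Benzoyl Group

This account rests on a few compounds, and the source may have more. Where it says the series, first, only, none or still open, it means among the compounds named here.

Of the compounds shown here, three sharing one core have been tested in an ADME assay on HEK-293T cells (Homo sapiens) for cytotoxicity, read by MTT assay, with a stated time of 24 h; on this read-out lower numbers stand for higher toxicity in this test and higher numbers for lower toxicity in this test. Compound 1 `Cc1ccccc1C(=O)n1c(-c2cn(-c3ccccc3)nc2-c2ccc(F)cc2)nc2ccccc21` gives 189000 nM. Compound 2 `Cc1ccc(-c2nn(-c3ccccc3)cc2-c2nc3ccccc3n2C(=O)c2ccncc2)cc1` gives 154000 nM. Compound 3 `O=C(c1ccccc1)n1c(-c2cn(-c3ccccc3)nc2-c2ccc(C(F)(F)F)cc2)nc2ccccc21` gives 168000 nM. Within the data shown here, on these three numbers compound 3 stands second highest, nearest to compound 2 and furthest from compound 1, but every gap between them lies within the usual scatter of this kind of measurement, so no compound can be called more or less toxic than another; all three are weakly toxic at most.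

Compound 4 `Cc1ccc(C(=O)n2c(-c3cn(-c4ccccc4)nc3-c3ccc(C(F)(F)F)cc3)nc3ccccc32)cc1` is not yet measured. It differs from compound 3 by a single change: methyl in place of hydrogen on an aromatic carbon. In words of structure, a benzoyl becomes a (4-methylphenyl)carbonyl. Among the measured compounds shown here, no measured pair here shows the effect of this exact change, so the expectation must rest on how flat the three known numbers are. Compound 4 is expected to stay in the same range as the others, so the step is estimated to be a 1.1-fold lower number from compound 3 to compound 4 (0.02 log units; within the scatter), that is, no change beyond the scatter in either direction. Compound 4 is therefore estimated at 160000 nM, with a plausible range from 80000 nM to 320000 nM.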

Compound 4, half-maximal cytotoxic concentration: 169000 nM
Compound 4: the middle estimate sits 1.1-fold (0.02 log units) below what was measured; the range from low to high includes it.
By their numbers in this assay, from the lowest: compounds 2, 3, 4 and 1 (each within the scatter of the next).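

In this assay, among these compounds, the methyl gives a 1.0-fold higher number from compound 3 to compound 4 (0.00 log units; within the scatter), the first direct reading of a single change in this set, since the earlier compounds differ from one another in more than one place. Adding this one carbon to the six-membered aromatic ring of carbon only, para to a large group, therefore produces no shift that can be told from the scatter, at least in a compound that also carries the 4-trifluoromethylphenyl group found in compound 3. That is one pair on one background, so it shows a single flat step rather than a general rule, and no measurement here offers an explanation for it.

Open, as far as these compounds go, is whether a different group at this same place, such as an amine, a carboxylic acid or a longer chain, would stay just as flat, and whether a methyl on another carbon of this ring would do the same. Also open, from the compounds shown here alone, is whether this change would behave alike on the other substitution patterns of the shared core, such as that of compound 1 or compound 2.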